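The source may report more compounds than this note shows. Statements on the series, on what has been measured and on what is new or still open speak of the compounds shown alone.

Among the measured compounds shown here, three ureas on one shared core have numbers so far. Compound 1 `O=C(Nc1nc(-c2cc3ccccc3o2)cs1)Nc1ccccc1F` gives 2630 nM in a physicochemical assay, with a stated time of 6 min; a lower number here means a stronger inhibitor, a higher number a weaker inhibitor; compound 2 `O=C(Nc1ccc(F)cc1)Nc1nc(-c2cc3ccccc3o2)cs1` gives 1130 nM in this assay; compound 3 `O=C(Nc1cccc(F)c1)Nc1nc(-c2cc3ccccc3o2)cs1` gives 4520 nM in this assay, the highest of the three numbers, though its gap to compound 1 is within the scatter and only its gap to compound 2 lies beyond it. Every measured step moves the fluoro to another place on the phenyl: a 2.3-fold lower number from compound 1 to compound 2 (0.37 log units; beyond the scatter), a 1.7-fold higher number from compound 1 to compound 3 (0.24 log units; within the scatter), a 4.0-fold higher number from compound 2 to compound 3 (0.60 log units; beyond the scatter). Compound 4 `O=C(Nc1cccc(Cl)c1)Nc1nc(-c2cc3ccccc3o2)cs1` instead carries chloro in place of fluoro on an aromatic carbon. For the measured compounds named here, no measured step exchanges one halogen for another, so nothing here fixes its size; the step is expected to stay within the scatter, a 1.3-fold lower number from compound 3 to compound 4 (0.11 log units; within the scatter). Compound 4 is therefore estimated at 3500 nM, within 1500 nM to 9000 nM.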

Compound 4, half-maximal inhibitory concentration: 14100 nM
Beside the measured number, compound 4's estimate is 4.0-fold (0.61 log units) below it, outside the stated range (above it).
By their numbers in this assay, from the lowest: compound 2; then compounds 1 and 3 (each within the scatter of the next); then compound 4.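

In this assay chloro in place of fluoro on this aromatic carbon is not a silent exchange (a 3.1-fold higher number from compound 3 to compound 4 (0.49 log units; beyond the scatter)), which the fluoro moves alone could not show. The 3-chlorophenyl urea also stands apart from the other two fluoro ureas (a 5.4-fold higher number from compound 1 to compound 4 (0.73 log units; beyond the scatter)) and (a 12-fold higher number from compound 2 to compound 4 (1.10 log units; beyond the scatter)), the second being the largest step in the set. Nothing measured here accounts for this shift.

Open, going by these compounds, is whether bromo or methyl at this place would continue the rise. Also open, on these data alone, is whether chloro would keep the order seen for fluoro elsewhere on the phenyl.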